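Spirocyclic amides: aminopyridine change from compound 2 to compound 4

The source may report more compounds than this note shows. Statements on the series, on what has been measured and on what is new or still open speak of the compounds shown alone.

Measured in a functional assay on HEK293 cells for antagonist activity at Orexin receptor type 2 (Homo sapiens), read by FLIPR and calcium flux (on this read-out lower numbers stand for lower potency and higher numbers for higher potency (the scale is a negative logarithm)), so far:
compound 1 `O=C(c1ncccc1-c1ncccn1)N1CC2(CC2)C[C@H]1CNc1ccc(C(F)(F)F)cn1` gives 5
compound 2 `Cc1nc(C(=O)N2CC3(CC3)C[C@H]2CNc2cc(C(F)(F)F)ccn2)c(-c2ccccc2)s1` gives 8.5
compound 3 `Cc1ccc(-c2ncccn2)c(C(=O)N2CC3(CC3)C[C@H]2CNc2cc(C(F)(F)F)ccn2)c1` gives 7.8

Compound 2 holds the highest number of the three in this assay; compound 3 sits closer to it and compound 1 far lower, both gaps beyond the scatter. For the measured compounds named here, no two of the measured compounds differ in a single place, so no step between them can be read off.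

Compound 4 `Cc1nc(C(=O)N2CC3(CC3)C[C@H]2CNc2ccc(C(F)(F)F)cn2)c(-c2ccccc2)s1` is not yet measured. It keeps the core and the thiazole side of compound 2 and differs only on the amine: 5-(trifluoromethyl)pyridin-2-yl in place of 4-(trifluoromethyl)pyridin-2-yl on an amine nitrogen. The same entering group is present in compound 1. Going by the values given here, compound 1 also carries a different aryl amide portion, so it does not differ from compound 2 in one place and no step between the two can be read off.

Among the compounds with values here, with no clean precedent, the expectation for this assay is a modest loss, a number 0.90 log units lower from compound 2 to compound 4 (beyond the scatter), though a result within the scatter of compound 2 would not be surprising. Compound 4 is estimated at 7.6, expected to fall between 6.6 and 8.6.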

Compound 4, negative logarithm of the antagonist equilibrium constant: 7.7
For compound 4 the middle estimate is 0.10 log units below the measured one; measured number inside the range.
By their numbers in this assay, from the lowest: compound 1; then compounds 4 and 3 (each within the scatter of the next); then compound 2.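

In this assay, for the compounds shown here, 5-(trifluoromethyl)pyridin-2-yl in place of 4-(trifluoromethyl)pyridin-2-yl on an amine nitrogen gives a number 0.80 log units lower from compound 2 to compound 4 (beyond the scatter), the first single-place reading; the two compounds have the same atoms, joined differently, so at this position the number depends on how the pyridine and the trifluoromethyl group are arranged and not on composition alone. Compound 4 also pairs with compound 1 on the amine side, since the two differ only in the amide portion: with the same amine group, compound 4 gives 7.7 and compound 1 gives 5, so the thiazole side of compound 4 keeps a much higher printed number. No measurement shown here bears on why the change has this size.

On these data alone, whether the step holds with the amide portion of compound 3 stays open, and other comparisons across the set cannot be read because those compounds differ in more than one place. Also open, as far as these compounds go, is how this amine position responds to a nitrile or a chlorine in place of trifluoromethyl, or to an unsubstituted pyridin-2-yl.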